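Solubility notes: piperidinyl to pyridinyl swap at the chain carbon

A few compounds are considered here, and "the series" means these few. Any claim that something is new, unique, unknown or untested is made for them only; others in the source may bear on it.

Compound 2 `COc1ccc2[nH]c(C(=O)N3CC(=O)N(Cc4ccccc4)[C@@H](CN4CCC(C)CC4)C3)cc2c1` gives 93100 nM in a physicochemical assay for solubility, read by spectrophotometry, in phosphate buffer, with a stated time of 2 h, at pH 7.4 (a lower number here means a less soluble compound, a higher number a more soluble compound), the highest of the three numbers seen so far. Compound 1 `COc1ccc2[nH]c(C(=O)N3CC(=O)N(Cc4ccccc4)[C@@H](CCc4ccccc4)C3)cc2c1` gives 4400 nM in this assay, and compound 3 `O=C(c1cc2cc(C3CC3)ccc2[nH]1)N1CC(=O)N(Cc2ccccc2)[C@@H](CN2CCN(Cc3ccccc3)CC2)C1` gives 12900 nM. Compound 4 `COc1ccc2[nH]c(C(=O)N3CC(=O)N(Cc4ccccc4)[C@@H](Cc4ccccn4)C3)cc2c1` is not yet measured; it differs from compound 2 in one place: pyridin-2-yl in place of 4-methylpiperidin-1-yl on a saturated chain carbon bound to a saturated ring carbon. Going by the values given here, the one measured step that bears on this position is a 21-fold higher number from compound 1 to compound 2 (1.33 log units; beyond the scatter), which shows that the group on this chain carbon moves the read-out strongly. Compound 4 carries an aromatic ring there, as compound 1 does, so its number is expected to fall between compound 1 and compound 2, nearer compound 1, because the step of a 21-fold higher number from compound 1 to compound 2 (1.33 log units; beyond the scatter) is the only large movement seen on this carbon. The expected step of a 9.3-fold lower number from compound 2 to compound 4 (0.97 log units; beyond the scatter) is therefore a drop beyond the scatter. Compound 4 is estimated at 10000 nM with a range from 3000 nM to 35000 nM.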

Compound 4, solubility: > 100000 nM
Compound 4: only a limit was reported; the forecaster's own chance of this, stated with the estimate: 5%; at least 10-fold (1.00 log units) between middle value and limit.
By their numbers in this assay, from the lowest: compound 1; then compound 3; then compound 2. At a limit, above all of these: compound 4.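

In this assay compound 4 gives > 100000 nM, a limit of the assay and not a number: the limit of > 100000 nM in this assay, at which 1 of the 4 values shown sits.

With pyridin-2-yl on the saturated chain carbon, the step is an at least 22-fold higher number from compound 1 to compound 4 (1.35 log units; beyond the scatter), so the top of the range is not confined to 4-methylpiperidin-1-yl, and an aromatic ring at this place does not by itself hold the number down, although compound 1 with benzyl stands lowest. The step of an at least 1.0-fold higher number from compound 2 to compound 4 (0.03 log units; that floor lies within the scatter) gives only a floor, so compound 2 and compound 4 cannot be ranked.

Still open, from the compounds shown here alone, is how far compound 4 lies past its limit. Also open, going by these compounds, is whether the ring nitrogen or the shorter link carries the step from benzyl; a phenyl or pyridin-3-yl group on this chain carbon would separate the two.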